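This account rests on a few compounds, and the source may have more. Where it says the series, first, only, none or still open, it means among the compounds named here.

Compound 3 `CN1CCC[C@H]1COc1cncc(Cl)c1` has been tested in an assay on membranes from brain for displacement of a labelled ligand from Neuronal acetylcholine receptor; alpha4/beta2 (Rattus norvegicus) (a higher number here means a weaker inhibitor, a lower number a stronger inhibitor), where compound 3 gives 0.6 nM. Among the measured compounds shown here, of the three compounds measured so far, compound 3 holds the second highest number. Compound 1 `CN1CCC[C@H]1COc1cccnc1` gives 0.15 nM, and the step of a 4.0-fold higher number from compound 1 to compound 3 (0.60 log units; beyond the scatter) came with chloro in place of hydrogen on an aromatic carbon. Compound 2 `Cc1ccncc1OC[C@@H]1CCCN1C` gives 4.12 nM, and the step of a 27-fold higher number from compound 1 to compound 2 (1.44 log units; beyond the scatter) came with methyl in place of hydrogen on an aromatic carbon, though on another aromatic carbon of the shared core than the chloro of compound 3.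

Compound 4 `Cc1cncc(OC[C@@H]2CCCN2C)c1` differs from compound 3 by methyl in place of chloro on an aromatic carbon. For the measured compounds named here, no measured step swaps methyl for chloro on one and the same carbon, so the two steps above only bracket the case: a substituent here cost a modest amount, while a methyl elsewhere cost far more. A small rise in the number is therefore expected for compound 4, estimated at 1.5 nM within a range of 0.4 nM to 6 nM. This expectation corresponds to a step of a 2.5-fold higher number from compound 3 to compound 4 (0.40 log units; beyond the scatter) in this assay.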

Compound 4, inhibition constant: 0.48 nM
The estimate for compound 4 lay 3.1-fold (0.49 log units) above the measured number, and the stated range covers the measured number.
By their numbers in this assay, from the lowest: compound 1; then compounds 4 and 3 (each within the scatter of the next); then compound 2.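

At this aromatic carbon, two atoms from the ring nitrogen, the change shows a 1.3-fold lower number from compound 3 to compound 4 (0.10 log units; within the scatter) in this assay and so chloro and methyl cannot be told apart here. Methyl on this carbon still differs from plain hydrogen, with a 3.2-fold higher number from compound 1 to compound 4 (0.51 log units; beyond the scatter) on record, and the same group on another aromatic carbon shows a much larger step, a 27-fold higher number from compound 1 to compound 2 (1.44 log units; beyond the scatter), so where the methyl sits counts for more than which of these two groups fills this position. No measurement shown here accounts for these differences. From the compounds shown here alone, it remains open whether an amine, a methoxy group or a carboxylic acid on this carbon would give a number close to those of compound 3 and compound 4. A longer chain such as ethyl or propyl is equally untested by these compounds.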